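Swapping phenyl for tert-butyl on a sulfur in a quinone series

The source may report more compounds than this note shows. Statements on the series, on what has been measured and on what is new or still open speak of the compounds shown alone.

Measured compounds:
- compound 1 `CCCSC1=CC(=O)C(C[C@]2(C)[C@@H](C)CC[C@]3(C)C(C)=CCC[C@@H]23)=CC1=O`: "not determined" (no result reported)
- compound 2 `CC1=CCC[C@H]2[C@](C)(CC3=CC(=O)C(SC(C)C)=CC3=O)[C@@H](C)CC[C@]12C`: "not determined" (no result reported)
- compound 3 `CC1=CCC[C@H]2[C@](C)(CC3=CC(=O)C(Sc4ccccc4)=CC3=O)[C@@H](C)CC[C@]12C`: 9900 nM

Four compounds share one core. They differ only in what sits on a sulfur of that core. In an ADME assay on PBMC cells (Homo sapiens) for cytotoxicity, read by MTT assay (on this read-out lower numbers stand for stronger inhibition and higher numbers for weaker inhibition), compound 3 gives 9900 nM. Compound 1 was run in this assay and gives "not determined" (no result reported). Compound 2 likewise gives "not determined" (no result reported). No number came back for either of these two, so compound 3 stands as the only compound with a reported value, and no comparison between measured compounds can be drawn from what is shown.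

Compound 4 `CC1=CCC[C@H]2[C@](C)(CC3=CC(=O)C(SC(C)(C)C)=CC3=O)[C@@H](C)CC[C@]12C` is the next step. Its structure differs from compound 3 in one place: tert-butyl in place of phenyl on a sulfur. For the measured compounds named here, there is no measured pair in this set that shows what such a change does, so the expectation for compound 4 rests on compound 3 alone. The estimated step of a 1.2-fold higher number from compound 3 to compound 4 (0.08 log units; within the scatter) is expected to lie within the usual scatter or only slightly beyond it, in the direction of weaker inhibition. Compound 4 is thus estimated to give 12000 nM in this assay, with a range from 5000 nM to 30000 nM.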

Compound 4, half-maximal inhibitory concentration: 21700 nM
For compound 4 the middle estimate is 1.8-fold (0.26 log units) below the measured one; low and high end bracket the measured number.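

In this assay, tert-butyl in place of phenyl on a sulfur gives a 2.2-fold higher number from compound 3 to compound 4 (0.34 log units; beyond the scatter). For the compounds shown here, this is the first measured pair, and it shows that the group on this sulfur can shift the read-out by a modest amount, towards weaker inhibition in this change. It also shows that the aromatic ring of the phenyl group is not needed for a number to be obtained here, since the tert-butyl compound, which has no ring in that place, still gives a value, but nothing measured here explains why the number moves.

Going by these compounds, compound 1 and compound 2 carry no number, so any steps to them cannot be read, and how their groups on the sulfur compare with phenyl and tert-butyl remains unknown. Also open, on these data alone, is what a group on this sulfur carrying an amine or a carboxylic acid would do to the read-out, and whether a longer chain would follow tert-butyl or phenyl.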